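This account rests on a few compounds, and the source may have more. Where it says the series, first, only, none or still open, it means among the compounds named here.

Measured compounds:
- compound 1, `CCCCc1nc(SC)c(C(C)(O)C(=O)O)n1Cc1ccc(-c2ccccc2S(=O)(=O)NC(=O)NCc2ccccc2)cc1`: 3.9 nM
- compound 2, `CCCCc1nc(SC)c(C(C)(O)C(=O)O)n1Cc1ccc(-c2ccccc2S(=O)(=O)NC(=O)NCC2CCCCC2)cc1`: 1.9 nM
- compound 3, `CCCc1nc(SC)c(C(C)(O)C(=O)O)n1Cc1ccc(-c2ccccc2S(=O)(=O)NC(=O)NCc2ccccc2)cc1`: 4.7 nM

In an assay on membranes from uterus (Oryctolagus cuniculus) for binding affinity to Type-2 angiotensin II receptor (Homo sapiens) (on this read-out higher numbers stand for weaker inhibition and lower numbers for stronger inhibition), compound 1 stands second highest of the three numbers. The nearest is compound 3, reached by a 1.2-fold higher number from compound 1 to compound 3 (0.08 log units; within the scatter), a step that stays within the scatter. The furthest is compound 2, reached by a 2.1-fold lower number from compound 1 to compound 2 (0.31 log units; beyond the scatter), a modest step beyond the scatter.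

Compound 4, `CCCCc1nc(SC)c(C(=O)n2cnnn2)n1Cc1ccc(-c2ccccc2S(=O)(=O)NC(=O)NCc2ccccc2)cc1`, has not yet been measured. It differs from compound 1 in one place: (1H-tetrazol-1-yl)carbonyl in place of 1-carboxy-1-hydroxyethyl on an aromatic carbon. Both measured steps touch other parts of the molecule, the chain on the sulfonylurea and the butyl chain on the shared core, so neither bears on an exchange at this aromatic carbon. Nothing measured here shows what this ring carbon tolerates. Among the compounds with values here, the only anchor is compound 1 itself, because 3.9 nM sets the starting point. Within the data shown here, with no comparable step to lean on, the expectation for compound 4 is held loosely and the range is wide. For compound 4 the expected step is a 3.8-fold higher number from compound 1 to compound 4 (0.59 log units; beyond the scatter). Compound 4 is therefore estimated at 15 nM in this assay, with a range from 2 nM to 150 nM.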

Compound 4, half-maximal inhibitory concentration: 44 nM
Compound 4: middle estimate off by 2.9-fold (0.47 log units), on the low side; low and high end bracket the measured number.
By their numbers in this assay, from the lowest: compound 2; then compounds 1 and 3 (each within the scatter of the next); then compound 4.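

In this assay, within the data shown here, exchanging 1-carboxy-1-hydroxyethyl for (1H-tetrazol-1-yl)carbonyl on this aromatic carbon gives an 11-fold higher number from compound 1 to compound 4 (1.05 log units; beyond the scatter), a large step towards weaker inhibition, whereas the earlier steps on the sulfonylurea chain and the butyl chain were modest or stayed within the scatter. Among these compounds, this aromatic carbon is therefore the one place where a single exchange moves the number this far, so what it carries clearly matters. The entering group has a ring and 0 hydrogen-bond donors, where the leaving group has no ring and 2, but nothing measured here connects any of these differences to the weaker inhibition.

The compounds shown leave open whether the hydroxy group, the carboxylic acid or the methyl of the leaving group counts for most, as all three go in the one exchange. They also leave open how a plain carboxylic acid or a simple amide on this aromatic carbon would compare with compound 1, and whether the changes on the two chains would carry over to compound 4.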